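The compounds below may be only part of what the source reports. "The series", "measured", "known", "first", "only" and "open" are said of these compounds alone.

Compound 1, `Cc1ccc(CSc2cc(Cl)c(C)cc2S(=O)(=O)/N=C(\N)n2nc(C)cc2-c2ccccc2)cc1`, gives 0.176 h in an ADME assay on microsomes from liver (Homo sapiens) for metabolic stability, read by LC-MS, using NADPH, tested at 5 uM; on this read-out higher numbers stand for a longer-lived compound and lower numbers for a shorter-lived compound.
Compound 2, `Cc1cc(S(=O)(=O)/N=C(\N)n2nccc2-c2ccccc2)c(SCc2cccc3ccccc23)cc1Cl`, gives 0.268 h in this assay.
Compound 3, `Cc1cc(S(=O)(=O)/N=C(\N)n2nccc2-c2ccccc2)c(SCc2ccc(Cl)cc2)cc1Cl`, gives 0.34 h in this assay.

Compound 1 stands at the lowest of the three numbers, yet its gaps to compound 2 and to compound 3 both fall within the scatter, so the three compounds cannot be ordered. Compound 4, `Cc1cc(-c2ccccc2)n(/C(N)=N/S(=O)(=O)c2cc(C)c(Cl)cc2SCc2ccccc2Cl)n1`, differs from compound 1 in one place: 2-chlorophenyl in place of 4-methylphenyl on a saturated chain carbon bound to a sulfur. Among the compounds with values here, the only measured step at that place is a 1.3-fold higher number from compound 2 to compound 3 (0.10 log units; within the scatter), which stays within the scatter. Within the data shown here, no measured step brings in the 2-chlorophenyl group itself. The step from compound 1 to compound 4 in this assay is therefore expected to stay within the scatter, as a 1.3-fold higher number from compound 1 to compound 4 (0.10 log units; within the scatter). Compound 4 is estimated at 0.22 h, with a range from 0.1 h to 0.5 h.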

Compound 4, half-life: 0.163 h
Compound 4: the middle estimate sits 1.3-fold (0.13 log units) above what was measured, within the range that was stated.
By their numbers in this assay, from the lowest: compounds 4, 1, 2 and 3 (each within the scatter of the next, the first and the last beyond it).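

Putting 2-chlorophenyl in place of 4-methylphenyl on a saturated chain carbon bound to a sulfur gives a 1.1-fold lower number from compound 1 to compound 4 (0.03 log units; within the scatter) in this assay, so this second step at the place also stays within the scatter. It extends that reading to the core of compound 1 and to a group carrying chlorine in the 2-position. Nothing available accounts for this result.

On these data alone, whether an amine or a carboxylic acid at this place would give a step beyond the scatter stays open. So does the effect of replacing the sulfur itself.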